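Trifluoromethoxy swap in a series at the assay limit

The compounds below may be only part of what the source reports. "The series", "measured", "known", "first", "only" and "open" are said of these compounds alone.

Measured so far in an ADME assay on HEK293 cells (Homo sapiens) for cytotoxicity, read by luminescence, with a stated time of 72 h; a lower number here means that less compound is needed, a higher number that more compound is needed for the effect:
compound 1 `CCOC(=O)c1c(-c2cccc(OC(F)(F)F)c2)[nH]c2cc(OC)ccc2c1=O`: > 22000 nM, a limit
compound 2 `CCOC(=O)c1c(-c2cccc(OC(F)(F)F)c2)[nH]c2cc(OC(F)(F)F)ccc2c1=O`: > 22000 nM, a limit
compound 3 `CCOC(=O)c1c(-c2cccc(OC)c2)[nH]c2cc(C(F)(F)F)ccc2c1=O`: > 22000 nM, a limit

Compound 3 has no number in this assay, only the limit > 22000 nM. The whole set stands at one reading: the limit of > 22000 nM in this assay, at which 3 of the 3 values shown sit.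

Compound 4 `CCOC(=O)c1c(-c2cccc(OC(F)(F)F)c2)[nH]c2cc(C(F)(F)F)ccc2c1=O` is not yet measured and follows from compound 3 by a single change: trifluoromethyl in place of methyl on an oxygen on an aromatic ring. The same methoxy to trifluoromethoxy change has one measured precedent, a step that the two limits leave unreadable from compound 1 to compound 2. That precedent therefore gives neither a size nor a direction. No step beyond the scatter is expected, and a move in either direction remains possible.

The expectation rests on compound 3 and its limit of > 22000 nM. As a step, the expectation is a step that the limit leaves unreadable from compound 3 to compound 4. Compound 4 is estimated at 25000 nM, with an expected range of 15000 nM to 50000 nM, and will most likely be reported only as a limit.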

Compound 4, half-maximal effective concentration: > 22000 nM
Compound 4: a limit, no number; the forecaster's own chance of this, stated with the estimate: 85%; the middle value is on the limit's open side.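

Compound 4 also stands only as a limit, and its steps from compound 1, compound 2 and compound 3 cannot be read. The set keeps a single reading: the limit of > 22000 nM in this assay, at which 4 of the 4 values shown sit.

The compounds shown leave open the size and direction of the methoxy to trifluoromethoxy change in this assay.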